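Thiocarbamate phosphate esters: ring swap at the thiocarbonyl

A few compounds are considered here, and "the series" means these few. Any claim that something is new, unique, unknown or untested is made for them only; others in the source may bear on it.

Measured so far:
compound 1 `CCCCCCCCOP(=O)(O)OCCSC(=S)N1CCCCCC1` — 27000 nM
compound 2 `CCCCCCOP(=O)(O)OCCSC(=S)N1CCCCCC1` — 17200 nM

In a functional assay on MDA-MB-231 cells (Homo sapiens) for inhibition, read by MTT assay, with stated times of 18 h and 4 h (on this read-out lower numbers stand for stronger inhibition and higher numbers for weaker inhibition), compound 1 gives 27000 nM. Compound 2 gives 17200 nM, and the two are separated by a 1.6-fold lower number from compound 1 to compound 2 (0.20 log units; within the scatter), a change on the chain only. Compound 3 `CCCCCCCCOP(=O)(O)OCCSC(=S)N1CCN(C)CC1` carries 4-methylpiperazin-1-yl in place of azepan-1-yl on a thiocarbonyl carbon. Going by the values given here, no measured step touches the group on the thiocarbonyl carbon, so the chain step offers no guide to this change. With only the two values of compound 1 and compound 2 to rest on, compound 3 is expected to show a 1.1-fold higher number from compound 1 to compound 3 (0.05 log units; within the scatter), estimated at 30000 nM with a range from 8000 nM to 100000 nM.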

Compound 3, half-maximal inhibitory concentration: 58500 nM
Compound 3: the middle estimate sits 2.0-fold (0.29 log units) below what was measured, within the range that was stated.
By their numbers in this assay, from the lowest: compounds 2 and 1 (each within the scatter of the next); then compound 3.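

In this assay the group on the thiocarbonyl carbon does register: 4-methylpiperazin-1-yl in place of azepan-1-yl gives a 2.2-fold higher number from compound 1 to compound 3 (0.34 log units; beyond the scatter) and so moves the read-out, unlike the chain step. Ring size and the second ring nitrogen change together in this swap, so the single step cannot separate them. Nothing available explains the step.

Open, from the compounds shown here alone, is where a piperidin-1-yl or morpholin-4-yl group on the thiocarbonyl carbon would fall, which would help separate ring size from the second ring nitrogen. Also open, going by these compounds, is whether the swap gives a similar step on the hexyl chain of compound 2.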